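The compounds below may be only part of what the source reports. "The series", "measured", "known", "first", "only" and "open" are said of these compounds alone.

Of the compounds shown here, three with a shared core have been tested in a functional assay on cells (leukaemia cell line, Homo sapiens) for inhibition, read by sulforhodamine B assay, with a stated time of 48 h; a lower number here means that less compound is tolerated, a higher number that more compound is tolerated: compound 1 `O=S(=O)(Nc1ccc(Cl)cc1Cl)c1ccc(-c2cnc(C3CC3)o2)cc1`, compound 2 `O=S(=O)(Nc1ccc(Cl)c(F)c1)c1ccc(-c2cnc(C3CC3)o2)cc1` and compound 3 `COc1cc(NS(=O)(=O)c2ccc(-c3cnc(C4CC4)o3)cc2)ccc1F`. They differ only in the group on a sulfonamide nitrogen. In this assay compound 1 gives > 100000 nM, which is a limit of the assay and not a number. Compound 2 gives > 100000 nM, again a limit. Compound 3 gives > 100000 nM, also a limit. Compound 3 therefore has no number of its own, and the whole set shares (the limit of > 100000 nM in this assay, at which 3 of the 3 values shown sit).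

Compound 4 `Cc1cc(Cl)cc(NS(=O)(=O)c2ccc(-c3cnc(C4CC4)o3)cc2)c1` carries 3-chloro-5-methylphenyl in place of 4-fluoro-3-methoxyphenyl on a sulfonamide nitrogen. Going by the values given here, three measured steps concern this same place: a step that the two limits leave unreadable from compound 1 to compound 2, a step that the two limits leave unreadable from compound 1 to compound 3 and a step that the two limits leave unreadable from compound 2 to compound 3. None of them has a readable size, so they offer no direction for the new change. All they show is that three different groups at this place left the compounds at the same limit. In this assay no step beyond the usual scatter is therefore expected, and compound 4 may well return only a limit too. The estimated change is a number no higher from compound 3 to compound 4 (the limit leaves the size open). For compound 4 the estimated value is 100000 nM, with an expected range from 40000 nM to 200000 nM.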

Compound 4, concentration lethal to 50% of the cells: 84900 nM
For compound 4 the middle estimate is 1.2-fold (0.07 log units) above the measured one; the measured number falls inside the stated range.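

In this assay compound 4 is the only one of the four with a number and not a limit, so 3-chloro-5-methylphenyl on a sulfonamide nitrogen gives this position its first readable value. Set against the other three compounds, the change reads as an at least 1.1-fold lower number from compound 3 to compound 4 (0.07 log units; that floor lies within the scatter) and as an at least 1.1-fold lower number from compound 2 to compound 4 (0.07 log units; that floor lies within the scatter) and as an at least 1.1-fold lower number from compound 1 to compound 4 (0.07 log units; that floor lies within the scatter) and each of these is only a floor: the true steps could be larger, but as printed none is shown to go beyond the usual scatter, so the new group cannot yet be said to have changed anything. The set as a whole still sits almost entirely at one edge of the assay: the limit of > 100000 nM in this assay, at which 3 of the 4 values shown sit.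

Going by these compounds, how far the three compounds at the limit really lie from compound 4 stays open, and with it whether this position can move the number at all. Also open, on these data alone, is whether a group of another kind on a sulfonamide nitrogen, such as a carboxylic acid or a longer chain in place of the aromatic ring, would bring the number clearly down.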